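Adding Chloro to Compound 3: What to Expect

This account rests on a few compounds, and the source may have more. Where it says the series, first, only, none or still open, it means among the compounds named here.

Compound 1, `CCCC#Cc1cc(C)oc(=O)c1`: 17800 nM
Compound 2, `CCCCCC/C=C/c1cc(C)oc(=O)c1`: > 50000 nM
Compound 3, `Cc1cc(-c2ccccc2)cc(=O)o1`: > 50000 nM

In a functional assay on K562 cells (Homo sapiens) for inhibition (on this read-out higher numbers stand for weaker inhibition and lower numbers for stronger inhibition), compound 1 gives 17800 nM as an actual number. For compound 2 the reading > 50000 nM is a limit of the assay, not a number. For compound 3 the reading > 50000 nM is likewise a limit of the assay. Compound 3 thus stands at the limit of > 50000 nM in this assay, at which 2 of the 3 values shown sit, and has no exact number of its own.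

Compound 4, `Cc1cc(-c2ccc(Cl)cc2)cc(=O)o1`, has not yet been measured. It differs from compound 3 by chloro in place of hydrogen on an aromatic carbon. Going by the values given here, no measured pair here shows this same change, so there is no ground to expect a step beyond the scatter. Compound 4 is therefore expected to fall near 60000 nM (range 20000 nM to 200000 nM), and the step from compound 3 to compound 4 is expected to be a step that the limit leaves unreadable from compound 3 to compound 4.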

Compound 4, half-maximal inhibitory concentration: > 50000 nM
Compound 4: a limit, no number; the forecaster's own chance of this, stated with the estimate: 70%; the middle value lies beyond the limit too.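

Going by these compounds alone, compound 3 and compound 4 each give a limit rather than a number in this assay, so no step between them can be read: the limit of > 50000 nM in this assay, at which 3 of the 4 values shown sit. As far as these compounds go, whether chloro in place of hydrogen changes inhibition at all remains open.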